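The source may report more compounds than this note shows. Statements on the series, on what has been measured and on what is new or still open speak of the compounds shown alone.

Compound 1 `O=C(CCc1cccc2c1B(O)OC2)Nc1ccccc1`: 200 nM
Compound 2 `O=C(CCc1cccc2c1B(O)OC2)Nc1ccc(Br)cc1`: 9200 nM
Compound 3 `CC(C)(C)c1ccc(NC(=O)CCc2cccc3c2B(O)OC3)cc1`: 4200 nM

In a functional assay on SK-OV-3 cells (Homo sapiens) for antiproliferative activity, read by MTT assay, with a stated time of 72 h (on this read-out higher numbers stand for weaker inhibition and lower numbers for stronger inhibition), compound 1 gives 200 nM, the lowest of the three numbers, and the other two compounds lie well above it. Compound 4 `COc1ccccc1NC(=O)CCc1cccc2c1B(O)OC2` has not yet been measured. Its difference from compound 1 is methoxy in place of hydrogen on an aromatic carbon, which is methoxy in place of hydrogen on an aromatic carbon.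

Within the data shown here, two measured steps bear on this change, as each also replaces a hydrogen on an aromatic carbon. Bromo gives a 46-fold higher number from compound 1 to compound 2 (1.66 log units; beyond the scatter), and tert-butyl gives a 21-fold higher number from compound 1 to compound 3 (1.32 log units; beyond the scatter). Both steps are large and both go upward, and neither of the other two compounds goes against that direction. The step between those two substituents, a 2.2-fold lower number from compound 2 to compound 3 (0.34 log units; beyond the scatter), is modest.

Among the measured compounds shown here, no measured compound carries methoxy, so these steps guide the direction firmly but the size only loosely. A rise in the number is therefore expected, probably smaller than either measured step, with a wide margin. The expected change is a 5.0-fold higher number from compound 1 to compound 4 (0.70 log units; beyond the scatter). Compound 4 is estimated at 1000 nM, with an expected range from 250 nM to 5000 nM.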

Compound 4, half-maximal inhibitory concentration: 200 nM
Estimate against measurement, compound 4: 5.0-fold (0.70 log units) above; the whole stated range lies above it.
By their numbers in this assay, from the lowest: compounds 1 and 4 (each within the scatter of the next); then compound 3; then compound 2.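

In this assay, the step of no change at the digits printed from compound 1 to compound 4 (within the scatter) shows that this ring of compound 1 can carry methoxy ortho to a large group with no change in the number. The earlier steps, a 46-fold higher number from compound 1 to compound 2 (1.66 log units; beyond the scatter) and a 21-fold higher number from compound 1 to compound 3 (1.32 log units; beyond the scatter), went sharply upward and could have suggested that any substituent on this ring raises the number; compound 4 is the one compound shown that goes against that reading. Nothing measured here explains why methoxy at this place leaves the number level.

Compound 4 differs from compounds 2 and 3 both in the group and in the ring carbon that carries it, so the compounds shown cannot separate the effect of the group from that of its place. On these data alone, it remains open whether bromo or an amine ortho to a large group would also stay level with compound 1, and whether methoxy on the carbon that holds bromo in compound 2 would raise the number as bromo does.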